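Swapping methoxy for chloro on a lactam

The source may hold more compounds than are shown below. What is called first, only, known or untested is meant among the compounds shown, and "the series" means these compounds.

In a functional assay on the whole organism with Rattus norvegicus as the target, at a dose of 25 mg/kg (on this read-out lower numbers stand for less inhibition and higher numbers for more inhibition at the one dose given (going by the name of the read-out)), compound 1 (`COc1ccc(N2C(=O)C(C)(C)c3cccnc32)cc1`) gives 0%, the lowest of the two numbers recorded so far. Within the data shown here, the only other measured compound, compound 2 (`CC(C)(C(=O)O)c1cccnc1Nc1ccc(Cl)cc1`), is built on a different, ring-opened arrangement and gives 14% in this assay, a number higher than that of compound 1 by a margin beyond the usual scatter. Compound 3 (`CC1(C)C(=O)N(c2ccc(Cl)cc2)c2ncccc21`) keeps the core of compound 1 and differs from it in one place: chloro in place of methoxy on an aromatic carbon, on an aromatic carbon of a six-membered aromatic ring of carbon only, para to a large group. Among the measured compounds shown here, no step between two measured compounds exists for such an exchange, so nothing measured here speaks to its size. Because compound 1 gives 0% in this assay, the expected step is a number 5 percentage points higher from compound 1 to compound 3 (within the scatter), no movement beyond the scatter. For compound 3 the estimate in this assay is 5%, with a range from 0% to 20%.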

Compound 3, a percentage reported as inhibition, in the whole organism at one dose (the size of the read-out at that dose, not a potency): 13%
Beside the measured number, compound 3's estimate is 8 percentage points below it, within the range that was stated.
By their numbers in this assay, from the lowest: compound 1; then compounds 3 and 2 (each within the scatter of the next).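

In this assay, chloro in place of methoxy on an aromatic carbon, para to a large group, gives a number 13 percentage points higher from compound 1 to compound 3 (beyond the scatter), the first step measured at this position. It shows that the read-out at the one dose given responds to a change at this place on the core of compound 1, though the step is modest and rests on a single exchange, so it sets no trend for other groups. No measurement shown accounts for the size or direction of this step.

The compounds shown leave open how an amine, a carboxylic acid or a longer chain such as ethoxy on the same aromatic carbon would read out. They also leave open whether the step from methoxy to chloro would persist at other doses.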